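This account rests on a few compounds, and the source may have more. Where it says the series, first, only, none or still open, it means among the compounds named here.

For the measured compounds named here, only two compounds have been tested so far in a functional assay on HeLa cells (Homo sapiens) for antiproliferative activity, read by MTT assay, with a stated time of 72 h; a lower number here means a stronger inhibitor, a higher number a weaker inhibitor. Compound 1 (`CCNC(=O)c1cc(Oc2ccc(NC(=O)c3nn(-c4ccc(Br)cc4F)c(=O)cc3C)cc2)ccn1`) gives "not active" (no number reported), with no number reported. Going by the values given here, compound 2 (`CNC(=O)c1cc(Oc2ccc(NC(=O)c3nn(-c4ccccc4Cl)c(=O)cc3C)cc2F)ccn1`) gives 9870 nM, the only number available, so it cannot yet be ranked against another measured value.

The next compound, compound 3 (`CNC(=O)c1cc(Oc2ccc(NC(=O)c3nn(-c4ccccc4)c(=O)cc3C)cc2F)ccn1`), comes from compound 2 through one small edit: hydrogen in place of chloro on an aromatic carbon. Put simply, this is hydrogen in place of chloro on an aromatic carbon, turning the 2-chlorophenyl into phenyl. Among the compounds with values here, no measured pair in this set differs in one place only, so there is no earlier step to use as a guide.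

The expectation therefore rests on compound 2 alone, at 9870 nM. No shift beyond the usual scatter of this assay is expected, and neither direction is favoured. The estimated change is small, a 1.1-fold lower number from compound 2 to compound 3 (0.04 log units; within the scatter). A result with no number, like that of compound 1, also remains possible. For compound 3 the expected value is 9000 nM, with an estimated range of 3500 nM to 25000 nM.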

Compound 3, half-maximal inhibitory concentration: "not active" (no number reported)
For compound 3 the study gives words and no number; no gap can be computed for the estimate.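

For the compounds shown here, compound 2 gives 9870 nM while compound 3 gives "not active" (no number reported) in this assay and so no step from 2-chlorophenyl to phenyl can be read between these two compounds. Nothing at hand bears on this result. The compounds shown leave open how the antiproliferative effect of compound 3 compares in size with that of compound 2.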